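From vinyl to allyl on the aromatic ring

The source may report more compounds than this note shows. Statements on the series, on what has been measured and on what is new or still open speak of the compounds shown alone.

- compound 1 `COC(=O)[C@@H]1CN(C)CC[C@@H]1c1ccc2ccccc2c1`: 23 nM
- compound 2 `COC(=O)[C@H]1CN(C)CC[C@@H]1c1ccc2ccccc2c1`: > 1000 nM, which is a limit
- compound 3 `C=Cc1ccc([C@H]2CCN(C)C[C@H]2C(=O)OC)cc1`: 144 nM

In a functional assay (brain) with Rattus norvegicus as the target (on this read-out higher numbers stand for weaker inhibition and lower numbers for stronger inhibition), compound 3 at 144 nM has the higher of the two exact numbers, and compound 1 sits lower at 23 nM. Compound 4 `C=CCc1ccc([C@H]2CCN(C)C[C@H]2C(=O)OC)cc1` carries allyl in place of vinyl on an aromatic carbon. Among the compounds with values here, the only measured step, an at least 43-fold higher number from compound 1 to compound 2 (1.63 log units; beyond the scatter), is large, but it comes with the fact that compounds 1 and 2 differ only in the configuration as drawn, so it does not speak to this change of group. Within the data shown here, compound 4 keeps the configuration of compound 3, and with no measured step on this group, the expectation stays close to compound 3 at 144 nM. A small rise in this assay is expected, a 1.4-fold higher number from compound 3 to compound 4 (0.14 log units; within the scatter), probably not beyond the scatter. For compound 4 the estimated value is 200 nM, with an expected range from 70 nM to 600 nM.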

Compound 4, half-maximal inhibitory concentration: > 1000 nM
Compound 4 gave a limit, no number; the forecaster's own chance of this, stated with the estimate: 7%; middle value at least 5.0-fold (0.69 log units) away from the limit.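

Before this result, the only measured step came with a change of configuration: the fact that compounds 1 and 2 differ only in the configuration as drawn Now a change of group alone, on an aromatic carbon para to a large group, gives an at least 6.9-fold higher number from compound 3 to compound 4 (0.84 log units; beyond the scatter) in this assay. Allyl differs from vinyl by only one carbon, so at this position a small change of group can matter.

Compound 4 gives > 1000 nM, which is a limit. As far as these compounds go, whether an ethyl or a propyl group here would behave more like vinyl or more like allyl stays open.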